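Carboxyethyl Amide Replaces Hydroxymethyl Branch on Shared Core

The source may hold more compounds than are shown below. What is called first, only, known or untested is meant among the compounds shown, and "the series" means these compounds.

Measured compounds:
Compound 1 `CCn1c(C(=O)N[C@H](CO)C(C)C)ccc1C(CC)(CC)c1ccc(OCS(=O)(=O)c2ccccc2)c(C)c1` — 25500 nM
Compound 2 `CCn1c(C(=O)N[C@H](CO)CCO)ccc1C(CC)(CC)c1ccc(OCS(=O)(=O)c2ccccc2)c(C)c1` — 28500 nM

Compounds 1 and 2 share one core and differ only in the group on the amide-type nitrogen. In a functional assay on MCF7 cells (Homo sapiens) for antiproliferative activity, read by MTT assay, with a stated time of 24 h (on this read-out higher numbers stand for weaker inhibition and lower numbers for stronger inhibition), compound 1 gives 25500 nM, and compound 2 gives 28500 nM. The step of a 1.1-fold higher number from compound 1 to compound 2 (0.05 log units; within the scatter) is within the scatter, so compound 1 holds the lower of the two numbers without any claim of order over compound 2, its nearest neighbour.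

Compound 3 `CCn1c(C(=O)NCCC(=O)O)ccc1C(CC)(CC)c1ccc(OCS(=O)(=O)c2ccccc2)c(C)c1` is the unmeasured analogue. Its change from compound 1 is 2-carboxyethyl in place of 1-(hydroxymethyl)-2-methylpropyl on an amide-type nitrogen. Within the data shown here, the one measured step, from compound 1 to compound 2, also exchanged the substituent on this nitrogen and left the number within the scatter; it bears on the new step only loosely, since the 2-carboxyethyl group is carried by neither measured compound and the defined stereocentre is lost. On that thin basis the expected step for compound 3 is a 1.3-fold higher number from compound 1 to compound 3 (0.10 log units; within the scatter), a modest move toward a higher number that may still lie within the scatter. Compound 3 is therefore estimated at 32000 nM, in a range from 12000 nM to 85000 nM.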

Compound 3, half-maximal inhibitory concentration: > 50000 nM
Compound 3 gave a limit, no number; the forecaster's own chance of this, stated with the estimate: 10%; middle value at least 1.5-fold (0.19 log units) from the limit.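

In this assay compound 3 gives > 50000 nM, which is a limit of the assay and not a number. Among these compounds, this is the first substituent on the amide-type nitrogen to yield no number, whereas the hydroxyl-bearing groups of compounds 1 and 2 both gave one. The two steps to compound 3 are known only as floors, an at least 1.9-fold higher number from compound 1 to compound 3 (0.29 log units; that floor lies within the scatter) and an at least 1.7-fold higher number from compound 2 to compound 3 (0.24 log units; that floor lies within the scatter), so the 2-carboxyethyl group may have shifted the reading, but neither floor shows a shift beyond the scatter.

The compounds shown do not reveal how far past the limit compound 3 lies, nor whether the change in reading goes with the carboxylic acid, with the loss of the branched chain or with the loss of the hydroxyl group. A methyl ester of the 2-carboxyethyl group, a 3-carboxypropyl chain or an unbranched 2-hydroxyethyl group on the same nitrogen would each bear on these questions in this assay.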